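Moving the Amino Group Around the Phenoxy Ring

A few compounds are considered here, and "the series" means these few. Any claim that something is new, unique, unknown or untested is made for them only; others in the source may bear on it.

Compound 1, `CC(Nc1ccccc1Oc1ccc(Cl)cc1)=C1C(=O)CC(c2ccccc2)CC1=O`: in a functional assay on CCRF-CEM cells (Homo sapiens) for antiproliferative activity, read by cell counting, with a stated time of 96 h (on this read-out lower numbers stand for stronger inhibition and higher numbers for weaker inhibition), compound 1 gives 190 nM.
Compound 2, `CC(Nc1ccccc1Oc1ccccc1)=C1C(=O)CC(c2ccccc2)CC1=O`: in this assay compound 2 gives 170 nM.
Compound 3, `CC(Nc1ccccc1Oc1cccc(N)c1)=C1C(=O)CC(c2ccccc2)CC1=O`: in this assay compound 3 gives 42 nM.

Compound 3 has the lowest number of the three in this assay. Both steps that lead to it, a 4.5-fold lower number from compound 1 to compound 3 (0.66 log units; beyond the scatter) and a 4.0-fold lower number from compound 2 to compound 3 (0.61 log units; beyond the scatter), are beyond the scatter, while a 1.1-fold lower number from compound 1 to compound 2 (0.05 log units; within the scatter) is within it. Compound 4, `CC(Nc1ccccc1Oc1ccc(N)cc1)=C1C(=O)CC(c2ccccc2)CC1=O`, has not been measured. It differs from compound 3 by 4-aminophenyl in place of 3-aminophenyl on an oxygen on an aromatic ring. Among the compounds with values here, no measured step moves the amino group around its ring, so the bearing of the three compounds is indirect. The step of a 4.0-fold lower number from compound 2 to compound 3 (0.61 log units; beyond the scatter) shows that an amino group, as placed in compound 3, brings a modest gain; the step of a 1.1-fold lower number from compound 1 to compound 2 (0.05 log units; within the scatter) shows that compound 1, carrying 4-chlorophenyl, is not separated from compound 2 beyond the scatter. Whether the gain survives the move to 4-aminophenyl is not told by these data. Compound 4 is expected at 70 nM, with a range from 25 nM to 200 nM. The step of a 1.7-fold higher number from compound 3 to compound 4 (0.22 log units; within the scatter) that this estimate means is expected to be small, more likely toward a higher number than a lower one.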

Compound 4, half-maximal inhibitory concentration: 37 nM
Estimate against measurement, compound 4: 1.9-fold (0.28 log units) above; measured number inside the range.
By their numbers in this assay, from the lowest: compounds 4 and 3 (each within the scatter of the next); then compounds 2 and 1 (each within the scatter of the next).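

Moving the amino group, with 4-aminophenyl in place of 3-aminophenyl on an oxygen on an aromatic ring, leaves the number in this assay unchanged within the scatter, at a 1.1-fold lower number from compound 3 to compound 4 (0.06 log units; within the scatter). The gain seen with compound 3 therefore survives the move, as the modest step of a 4.6-fold lower number from compound 2 to compound 4 (0.66 log units; beyond the scatter) shows for amino in place of hydrogen. The step of a 5.1-fold lower number from compound 1 to compound 4 (0.71 log units; beyond the scatter) shows that amino in place of chloro brings a gain of similar size, so in these two compounds the gain is not tied to one of the two placements.

On these data alone, whether a hydroxyl, a methylamino or an acetamido group could stand in place of the amino group and keep this gain remains open. No measurement shown here bears on what lies behind the gain or on why the two placements read alike.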